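Isopropoxy in place of ethyl(methyl)amino on the shared core

The compounds below may be only part of what the source reports. "The series", "measured", "known", "first", "only" and "open" are said of these compounds alone.

In a functional assay on the whole organism with Rattus norvegicus as the target (on this read-out lower numbers stand for an effect already at smaller amounts and higher numbers for an effect only at larger amounts of compound), compound 1 `CCNc1cccc(NC(=O)C(=O)OCC)c1C#N` gives 0.03 mg/kg as its value, compound 2 `CCCNc1cccc(NC(=O)C(=O)OCC)c1C#N` gives 0.7 mg/kg and compound 3 `CCOC(=O)C(=O)Nc1cccc(N(C)CC)c1C#N` gives 0.5 mg/kg on the same scale. Compound 3 therefore sits within the scatter of compound 2 and far from compound 1. The next step leads to compound 4 `CCOC(=O)C(=O)Nc1cccc(OC(C)C)c1C#N` and is described as isopropoxy in place of ethyl(methyl)amino on an aromatic carbon with isopropoxy in place of ethyl(methyl)amino on an aromatic carbon. Two measured steps were large: a 23-fold higher number from compound 1 to compound 2 (1.37 log units; beyond the scatter) and a 17-fold higher number from compound 1 to compound 3 (1.22 log units; beyond the scatter) both came from adding a methyl to compound 1. Between the other two compounds the data show only a 1.4-fold lower number from compound 2 to compound 3 (0.15 log units; within the scatter) and nothing more. Among the compounds with values here, no measured step exchanges ethyl(methyl)amino for isopropoxy, so these steps bear on the new one only loosely, and the return to the low number of compound 1 has no support in the data. The expected change is no step beyond the scatter, namely a 1.3-fold lower number from compound 3 to compound 4 (0.10 log units; within the scatter) as a rough expectation. Compound 4 is estimated at 0.4 mg/kg within an expected range of 0.08 mg/kg to 2 mg/kg in this assay once measured.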

Compound 4, dose for half-maximal effect: 1 mg/kg
For compound 4 the middle estimate is 2.5-fold (0.40 log units) below the measured one; the measured number falls inside the stated range.
By their numbers in this assay, from the lowest: compound 1; then compounds 3, 2 and 4 (each within the scatter of the next).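

In this assay, within the data shown here, isopropoxy on this aromatic carbon brings the first oxygen-linked group to the position, and the exchange for ethyl(methyl)amino gives a 2.0-fold higher number from compound 3 to compound 4 (0.30 log units; within the scatter) with the same count of heavy atoms. The exchange for propylamino gives a 1.4-fold higher number from compound 2 to compound 4 (0.15 log units; within the scatter) and leaves compound 2, compound 3 and compound 4 within the scatter at this position, so among these three a nitrogen at the point of attachment makes no difference beyond the scatter, while the exchange for ethylamino gives a 33-fold higher number from compound 1 to compound 4 (1.52 log units; beyond the scatter) and leaves compound 1 apart from all the others. Nothing available explains these steps. The compounds shown leave open whether ethoxy, the oxygen counterpart of ethylamino, would reach the low number of compound 1 or stay with compound 4. Going by these compounds, how methoxy or a plain amino group would read in this assay also remains open.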